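Swapping the Ring on the Thiocarbonyl of Compound 2

The source may hold more compounds than are shown below. What is called first, only, known or untested is meant among the compounds shown, and "the series" means these compounds.

Compound 2 `Cc1ccnc(/C(N)=N/NC(=S)N2CCOCC2)c1` was tested in a functional assay on A-375 cells (Homo sapiens) for cytotoxicity, read by MTT assay, with a stated time of 72 h, tested at 1 uM (a lower number here means less inhibition of growth, a higher number more inhibition of growth at the concentration tested), and gives 43.2%. Among the three measured compounds it stands second highest: compound 3 `N/C(=N\NC(=S)N1CCSCC1)c1ccc(F)cn1` gives 55.1%, and compound 1 `N/C(=N\NC(=S)N1CCOCC1)c1ccccn1` gives 26.8%. Among the measured compounds shown here, the only measured step that changes a single place, a number 16.4 percentage points higher from compound 1 to compound 2 (beyond the scatter), concerns a methyl group and says nothing about the ring attached to the thiocarbonyl carbon. Compound 4 `Cc1ccnc(/C(N)=N/NC(=S)N2CCCC2)c1` differs from compound 2 by pyrrolidin-1-yl in place of morpholin-4-yl on a thiocarbonyl carbon. For the measured compounds named here, no measured step bears on this change, so the expectation rests on compound 2 alone, and the expected step of a number 0.2 percentage points lower from compound 2 to compound 4 (within the scatter) is taken as none beyond the scatter, with wide uncertainty. Compound 4 is therefore estimated at 43%, within a range from 23% to 63%.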

Compound 4, percent growth inhibition at one concentration: 69%
For compound 4 the middle estimate is 26 percentage points below the measured one; the measured number lies above the stated range.
By their numbers in this assay, from the lowest: compound 1; then compound 2; then compound 3; then compound 4.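

The ring on the thiocarbonyl carbon turns out to matter in this assay: pyrrolidin-1-yl in place of morpholin-4-yl gives a number 25.8 percentage points higher from compound 2 to compound 4 (beyond the scatter). This one change both removes the oxygen and turns a six-membered ring into a five-membered one, and a single step cannot separate the two. Nothing available explains the rise. Going by these compounds, whether piperidin-1-yl, a six-membered ring without oxygen, or an open dimethylamino group would give a similar number remains open. So does whether pyrrolidin-1-yl would raise the number on the core of compound 1.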